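The compounds below may be only part of what the source reports. "The series", "measured", "known", "first", "only" and "open" are said of these compounds alone.

Compound 1 `Cc1cc(C)c(C(=O)N[C@@H](CNC(=O)CO[C@@H]2C[C@@H](CNc3ccccn3)N(C(=O)OCc3ccccc3)C2)C(=O)O)c(C)c1` is the stronger of the two measured entries in an assay on a protein complex for inhibition of integrin alpha-5/beta-1 (Homo sapiens), read by ELISA; a lower number here means a stronger inhibitor, a higher number a weaker inhibitor: compound 1 gives 3.5 nM, while compound 2 `Cc1cc(C)c(S(=O)(=O)N[C@@H](CNC(=O)CO[C@@H]2C[C@@H](CNc3ccccn3)N(C(=O)CCc3ccccc3)C2)C(=O)O)c(C)c1` gives 25 nM, a gap that lies beyond the scatter; compound 2 differs from compound 1 in more than one place, so the two values are noted only side by side. Compound 3 `O=C(CO[C@@H]1C[C@@H](CNc2ccccn2)N(C(=O)OCc2ccccc2)C1)NC[C@H](NC(=O)c1ccccc1)C(=O)O` carries phenyl in place of 2,4,6-trimethylphenyl on a carbonyl carbon, phenyl in place of 2,4,6-trimethylphenyl on a carbonyl carbon. For the measured compounds named here, no measured pair isolates this change, so the expected step of a 5.7-fold higher number from compound 1 to compound 3 (0.76 log units; beyond the scatter) rests on judgement alone and is put as a loss beyond the scatter. For compound 3 the estimate is 20 nM, within 5 nM to 80 nM.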

Compound 3, half-maximal inhibitory concentration: 155 nM
For compound 3 the middle estimate is 7.8-fold (0.89 log units) below the measured one; measured number above the stated range.
By their numbers in this assay, from the lowest: compound 1; then compound 2; then compound 3.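

Phenyl in place of 2,4,6-trimethylphenyl on a carbonyl carbon gives the first single-place comparison in the series, and in this assay it reads a 44-fold higher number from compound 1 to compound 3 (1.65 log units; beyond the scatter). Activity at this position therefore depends strongly on the aryl substitution, although both groups are six-membered carbon aromatic rings with no hydrogen-bond donors, acceptors or net charge. Nothing available accounts for the loss.

As far as these compounds go, whether a single methyl or a chlorine on the phenyl would recover part of the loss remains open. So does whether the same change would carry over to the sulfonamide of compound 2.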